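Dimethylsulfamoyl in Place of (Ethylsulfanyl)carbonyl on the Ring Amine

The source may report more compounds than this note shows. Statements on the series, on what has been measured and on what is new or still open speak of the compounds shown alone.

Three measured compounds share one core and differ only in the group carried by the amine nitrogen of a six-membered non-aromatic ring. In a functional assay on CHO-K1 cells with Glucose-dependent insulinotropic receptor (Homo sapiens) as the target, read by a luciferase reporter, with a stated time of 5 h (a lower number here means a smaller maximal response, a higher number a larger maximal response), compound 1 `CC(C)OC(=O)N1CCC(Oc2ncnc3c2CCN3c2ccc(S(C)(=O)=O)cc2F)CC1` gives 91%, compound 2 `CSC(=O)N1CCC(Oc2ncnc3c2CCN3c2ccc(S(C)(=O)=O)cc2F)CC1` gives 135%, and compound 3 `CCSC(=O)N1CCC(Oc2ncnc3c2CCN3c2ccc(S(C)(=O)=O)cc2F)CC1` gives 128%. Compound 3 stands second highest of the three: its value and that of compound 2 lie within the usual scatter of each other, while compound 1 sits well below it. The two steps beyond the scatter, a number 44 percentage points higher from compound 1 to compound 2 (beyond the scatter) and a number 37 percentage points higher from compound 1 to compound 3 (beyond the scatter), both exchange an isopropoxy on a carbonyl carbon for a methylsulfanyl or an ethylsulfanyl; the step of a number 7 percentage points lower from compound 2 to compound 3 (within the scatter) shows that methyl in place of hydrogen on the chain carbon bound to sulfur changes little.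

Compound 4 `CN(C)S(=O)(=O)N1CCC(Oc2ncnc3c2CCN3c2ccc(S(C)(=O)=O)cc2F)CC1` is not yet measured. It differs from compound 3 by dimethylsulfamoyl in place of (ethylsulfanyl)carbonyl on an amine nitrogen in a ring. Going by the values given here, no measured step removes the carbonyl or introduces a sulfamoyl, so the earlier steps bear on this change only loosely: they show that the group at this nitrogen can shift the maximal response by a large amount, but not in which direction a sulfamoyl would move it. Compound 4 is therefore expected to land between the values seen so far, with an expected step of a number 23 percentage points lower from compound 3 to compound 4 (beyond the scatter) in this assay. The maximal response of compound 4 is estimated at 105%, ranging from 70% to 140%.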

Compound 4, largest response reached (reported as percent of maximum), in percent of the reference or control that the assay uses: 68%
Estimate against measurement, compound 4: 37 percentage points above, and the stated range ends above it.
By their numbers in this assay, from the lowest: compound 4; then compound 1; then compounds 3 and 2 (each within the scatter of the next).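

In this assay the dimethylsulfamoyl group on the amine nitrogen in the ring gives a lower maximal response than each of the three carbonyl-linked groups, with a number 60 percentage points lower from compound 3 to compound 4 (beyond the scatter) and a number 67 percentage points lower from compound 2 to compound 4 (beyond the scatter) as large steps and a number 23 percentage points lower from compound 1 to compound 4 (beyond the scatter) as a modest one. Going by these compounds alone, this settles what the earlier compounds could not: at this nitrogen, the change to a sulfamoyl moves the response downward, and compound 4 is the lowest of the four, below even the isopropoxycarbonyl of compound 1. The earlier compounds had shown only the rise from isopropoxycarbonyl to the two sulfanylcarbonyl groups, so the range of response reached through this one position now extends further down than they revealed.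

As far as these compounds go, how a dimethylcarbamoyl or a plain methylsulfonyl on this ring nitrogen would read remains open, and with it whether the fall follows the loss of the carbonyl, the sulfamoyl as a whole, or its dimethylamino part. Nothing available gives a reason for the fall in maximal response.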